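The source may report more compounds than this note shows. Statements on the series, on what has been measured and on what is new or still open speak of the compounds shown alone.

In a functional assay for inhibition, with Homo sapiens as the target (on this read-out lower numbers stand for stronger inhibition and higher numbers for weaker inhibition), compound 3 `CCCc1c(OCCCOc2ccc(C(=O)NC)c(OC)c2CC2CC2)ccc2c1OC(CCC(=O)O)CC2` gives 21.9 nM, compound 1 `CCCc1c(OCCCOc2ccc(C(=O)NC)c(OC)c2CC2CC2)ccc2c1O[C@H](CCC(=O)O)CC2` gives 24.4 nM and compound 2 `CCCc1c(OCCCOc2ccc(C(=O)NC)c(OC)c2CC2CC2)ccc2c1OC(C(=O)O)CC2` gives 13 nM. Compound 3 thus stands within the scatter of both others, with a 1.1-fold lower number from compound 1 to compound 3 (0.05 log units; within the scatter) and a 1.7-fold higher number from compound 2 to compound 3 (0.23 log units; within the scatter). Compound 4 `CCCc1c(OCCCOc2ccc(C(=O)NC)c(OC)c2CC2CC2)ccc2c1O[C@@H](CCC(=O)O)CC2` differs from compound 3 by the two compounds have the same atoms and bonds; at least one stereo element is drawn with a configuration in one of them and without one in the other: 1 of 1 stereo elements differ; a stereocentre at a saturated ring carbon is drawn without a configuration in compound 3 and R in compound 4: a stereocentre at a saturated ring carbon is drawn without a configuration in compound 3 and R in compound 4. The closest measured step is a 1.1-fold lower number from compound 1 to compound 3 (0.05 log units; within the scatter), where that kind of stereocentre is drawn S in compound 1 and without a configuration in compound 3. The second step concerns another change and bears less on this one. No step beyond the scatter is therefore expected, and the estimated step is a 1.1-fold lower number from compound 3 to compound 4 (0.04 log units; within the scatter). For compound 4 the expected value in this assay is 20 nM, with an estimated range of 8 nM to 50 nM.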

Compound 4, half-maximal inhibitory concentration: 10.7 nM
Estimate against measurement, compound 4: 1.9-fold (0.27 log units) above; the measured number falls inside the stated range.
By their numbers in this assay, from the lowest: compounds 4, 2, 3 and 1 (each within the scatter of the next, the first and the last beyond it).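

Earlier, drawing this saturated ring carbon as S or without a configuration gave no step beyond the scatter. In this assay, the R configuration now brings a 2.3-fold lower number from compound 1 to compound 4 (0.36 log units; beyond the scatter), and against the drawing without a configuration it brings a 2.0-fold lower number from compound 3 to compound 4 (0.31 log units; beyond the scatter). Both steps are modest, and the first can be read as an effect of configuration alone, because nothing else separates the two compounds: the fact that compounds 1 and 4 differ only in the configuration as drawn

Going by these compounds, compound 2 carries carboxy on that carbon with no configuration drawn, so it stays open whether R and S would separate there too. Also open, on these data alone, is how a longer carboxylic acid chain or an amine in place of 2-carboxyethyl would behave in either configuration.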